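Extending the chain to the methanesulfonamido group

The source may report more compounds than this note shows. Statements on the series, on what has been measured and on what is new or still open speak of the compounds shown alone.

Measured so far in an assay on HEK293 cells for displacement of a labelled ligand from NPC1-like intracellular cholesterol transporter 1 (Homo sapiens); a higher number here means a weaker inhibitor, a lower number a stronger inhibitor:
compound 1 `CC(C)(C)c1ccc(C(=O)N2CCC3(CC2)C(=O)N(CC(=O)N2CCCCC2CCO)CN3c2ccccc2)cc1` gives 6100 nM;
compound 2 `CC(C)(C)c1ccc(C(=O)N2CCC3(CC2)C(=O)N(CC(=O)NCNS(C)(=O)=O)CN3c2ccccc2)cc1` gives 3200 nM.

Among the compounds with values here, compound 2 holds the lowest of the two numbers; its only neighbour is compound 1, and the move between them is a 1.9-fold lower number from compound 1 to compound 2 (0.28 log units; within the scatter). Compound 3 `CC(C)(C)c1ccc(C(=O)N2CCC3(CC2)C(=O)N(CC(=O)NCCCCNS(C)(=O)=O)CN3c2ccccc2)cc1` differs from compound 2 by 3-(methanesulfonamido)propyl in place of methanesulfonamido on a saturated chain carbon bound to an amide-type nitrogen. Within the data shown here, no measured step lengthens this chain; the sole step, a 1.9-fold lower number from compound 1 to compound 2 (0.28 log units; within the scatter), replaced the whole amide substituent and stayed within the scatter, so no change beyond the scatter is expected in this assay. Compound 3 is expected near 3000 nM, estimated range 1000 nM to 9000 nM. Compound 3 thus carries an expected step of a 1.1-fold lower number from compound 2 to compound 3 (0.03 log units; within the scatter).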

Compound 3, half-maximal inhibitory concentration: 4500 nM
Compound 3: middle estimate off by 1.5-fold (0.18 log units), on the low side, and the stated range covers the measured number.
By their numbers in this assay, from the lowest: compounds 2, 3 and 1 (each within the scatter of the next).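

In this assay, 3-(methanesulfonamido)propyl in place of methanesulfonamido gives a 1.4-fold higher number from compound 2 to compound 3 (0.15 log units; within the scatter), so this added chain length brings no change beyond the scatter. Against the 2-(2-hydroxyethyl)piperidin-1-yl amide, the (4-(methanesulfonamido)butyl)amino group gives a 1.4-fold lower number from compound 1 to compound 3 (0.13 log units; within the scatter), which again leaves all three compounds within the scatter of one another. No available evidence bears on this result.

Still open, as far as these compounds go, is whether an amine or a carboxylic acid in place of methanesulfonamido would shift the number beyond the scatter. A longer chain carrying methanesulfonamido also remains an open case.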